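The source may report more compounds than this note shows. Statements on the series, on what has been measured and on what is new or still open speak of the compounds shown alone.

Measured in a functional assay on A549 cells (Homo sapiens) for antiproliferative activity, read by MTT assay, with a stated time of 96 h; a lower number here means a stronger inhibitor, a higher number a weaker inhibitor:
- compound 1 `CSC(=S)N/N=C1\CC2(CCCCC2)Oc2c1ccc1ccccc21`: 3990 nM
- compound 2 `O=C(N/N=C1\CC2(CCCCC2)Oc2c1ccc1ccccc21)Nc1ccc(Cl)cc1`: 9540 nM

Of these two, compound 2 has the higher number, which makes it the weaker inhibitor of the pair. Compound 3 `N/N=C1\CC2(CCCCC2)Oc2c1ccc1ccccc21` has not been measured yet. Its difference from compound 2 is hydrogen in place of (4-chlorophenyl)carbamoyl on an amine nitrogen: hydrogen takes the place of (4-chlorophenyl)carbamoyl on an amine nitrogen, while the shared core stays the same.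

Among the measured compounds shown here, only one measured step bears on this change. It swaps the group on that same amine nitrogen, and it is a 2.4-fold higher number from compound 1 to compound 2 (0.38 log units; beyond the scatter). That modest step is a single comparison, not a pattern, and neither measured compound carries a plain hydrogen at this place. The higher number came with the larger group in compound 2, so removing that group is expected to lower the number in this assay, but only slightly. The expected change is a 1.9-fold lower number from compound 2 to compound 3 (0.28 log units; within the scatter), which may be no larger than the usual scatter. For compound 3 the estimated value is 5000 nM, with an expected range of 1500 nM to 15000 nM.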

Compound 3, half-maximal inhibitory concentration: 12900 nM
Compound 3: the middle estimate sits 2.6-fold (0.41 log units) below what was measured, within the range that was stated.
By their numbers in this assay, from the lowest: compound 1; then compounds 2 and 3 (each within the scatter of the next).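

In this assay, hydrogen in place of (4-chlorophenyl)carbamoyl on an amine nitrogen gives (a 1.4-fold higher number from compound 2 to compound 3 (0.13 log units; within the scatter)), so at this position the large ring-bearing group cannot be told apart from no group at all. Compound 1 does stand apart from the plain hydrogen, with (a 3.2-fold higher number from compound 1 to compound 3 (0.51 log units; beyond the scatter)), which means that among these three compounds the number does not simply follow the size of the group: the group of 4 heavy atoms (2 carbon, 2 sulfur) in compound 1 gives the lowest number, while hydrogen and the group of 10 heavy atoms give numbers within the scatter of each other. Nothing available explains why these groups compare as they do.

The compounds shown leave open which part of the group in compound 1 goes with its lower number, a question that a longer chain in place of its methyl on sulfur, or an oxygen in place of one of its sulfurs, would address. They also leave open whether a small acetyl group on this nitrogen would behave like hydrogen or like the group in compound 1.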